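The source may hold more compounds than are shown below. What is called first, only, known or untested is meant among the compounds shown, and "the series" means these compounds.

Working notes on the series. In a functional assay on the whole organism (Central nervous system) with Mus musculus as the target (on this read-out higher numbers stand for an effect only at larger amounts of compound and lower numbers for an effect already at smaller amounts), compound 3 `O=C(CCC(=O)c1ccc(Cl)cc1)NCCCO` gives 325 mg/kg. Compound 1 `O=C(CCC(=O)c1ccc(F)cc1)NCCCO` gives 500 mg/kg and compound 2 `O=C(CCC(=O)c1ccc(Cl)c(Cl)c1)NCCCO` gives 500 mg/kg in this assay; both lie within the scatter of compound 3, so the three numbers cannot be ordered. The step to compound 4 `COc1ccc(C(=O)CCC(=O)NCCCO)cc1` is methoxy in place of chloro on an aromatic carbon. Among the compounds with values here, the two measured steps at the same place, a 1.5-fold lower number from compound 1 to compound 3 (0.19 log units; within the scatter) and a 1.5-fold lower number from compound 2 to compound 3 (0.19 log units; within the scatter), were both within the scatter; no measured step introduces a methoxy group. On that basis no change beyond the scatter is expected in this assay, so the step from compound 3 to compound 4 is estimated as a 1.2-fold higher number from compound 3 to compound 4 (0.09 log units; within the scatter). Compound 4 is therefore expected to give about 400 mg/kg, with a range from 200 mg/kg to 800 mg/kg.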

Compound 4, dose for half-maximal effect: 800 mg/kg
Compound 4: the middle estimate sits 2.0-fold (0.30 log units) below what was measured; the range from low to high includes it.
By their numbers in this assay, from the lowest: compounds 3, 1, 2 and 4 (each within the scatter of the next, the first and the last beyond it).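

In this assay, within the data shown here, methoxy in place of chloro gives the only step at this position that lies beyond the scatter, a modest one (a 2.5-fold higher number from compound 3 to compound 4 (0.39 log units; beyond the scatter)). Methoxy in place of fluoro stays within the scatter (a 1.6-fold higher number from compound 1 to compound 4 (0.20 log units; within the scatter)), so the size of the change at this position depends on which halogen it is read against. Nothing available explains this difference.

Open, on these data alone, is whether the step comes from the oxygen or from the methyl of methoxy. Also open, as far as these compounds go, is how an amine, a carboxylic acid or a longer ether chain such as butoxy would read at this position.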